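A Methoxy Group Added to Compound 1

The source may hold more compounds than are shown below. What is called first, only, known or untested is meant among the compounds shown, and "the series" means these compounds.

For the measured compounds named here, in an assay on isolated protein for inhibition of protein tyrosine phosphatase type IVA 3 (Homo sapiens), tested at 5 ug/mL (on this read-out lower numbers stand for less inhibition and higher numbers for more inhibition at the one concentration tested (going by the name of the read-out)), compound 1 `O=C1NC(=S)S/C1=C\C=C\c1ccccc1` gives 37.4%, the lowest of the three numbers measured so far. Compound 2 `O=C1NC(=S)S/C1=C\C=C\c1ccccc1OS(=O)(=O)c1ccccc1` gives 64.2% and compound 3 `O=C1NC(=S)S/C1=C\c1cc(Br)ccc1OCc1ccccc1Br` gives 65.2%; both stand beyond the scatter above compound 1, while the two of them lie within the scatter of each other. Compound 4 `COc1ccccc1/C=C/C=C1\SC(=S)NC1=O` has not yet been measured in this assay. It differs from compound 1 by methoxy in place of hydrogen on an aromatic carbon. Compounds 2 and 3 each carry an oxygen-linked group on a six-membered aromatic ring and score higher than compound 1, though neither is a single-change comparison. The step from compound 1 to compound 4 is expected to be a modest rise, a number 10.6 percentage points higher from compound 1 to compound 4 (beyond the scatter). Compound 4 is estimated at 48%, within a range of 30% to 66%.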

Compound 4, a percentage reported as inhibition, at one concentration (the size of the read-out at that concentration, not a potency): 41.7%
For compound 4 the middle estimate is 6.3 percentage points above the measured one; the measured number falls inside the stated range.
By their numbers in this assay, from the lowest: compounds 1 and 4 (each within the scatter of the next); then compounds 2 and 3 (each within the scatter of the next).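

In this assay, for the compounds shown here, the single change of hydrogen to methoxy, on an aromatic carbon ortho to a large group, gives a number 4.3 percentage points higher from compound 1 to compound 4 (within the scatter) and so offers the first one-place comparison. At this position, methoxy in place of hydrogen does not move the number beyond the usual scatter. No measured evidence bears on this result.

On these data alone, whether an amine or a carboxylic acid at this position would give a step beyond the scatter remains open. So does whether a longer chain on the oxygen would.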